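The source may report more compounds than this note shows. Statements on the series, on what has been measured and on what is new or still open speak of the compounds shown alone.

Measured so far:
compound 1 `S=c1oc(-c2ccc3c(c2)OCCO3)nn1CNC1CCCCC1` — 18400 nM
compound 2 `S=c1oc(-c2ccc3c(c2)OCCO3)nn1CNc1ccc(Cl)cc1` — 7270 nM

Both compounds share one core and differ only in the group carried on the amine nitrogen. In a functional assay, with a stated time of 6 min (on this read-out lower numbers stand for stronger inhibition and higher numbers for weaker inhibition), compound 1 gives 18400 nM, and compound 2 gives 7270 nM. Among the compounds with values here, the single measured step, a 2.5-fold lower number from compound 1 to compound 2 (0.40 log units; beyond the scatter), is therefore the whole of what is known about this position. On the numbers shown, compound 2 stands lowest of the two, with compound 1 as its only neighbour.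

Compound 3 `O=[N+]([O-])c1cccc(NCn2nc(-c3ccc4c(c3)OCCO4)oc2=S)c1` is not yet measured. It differs from compound 2 in one place: 3-nitrophenyl in place of 4-chlorophenyl on an amine nitrogen. Within the data shown here, the only step that bears on it is a 2.5-fold lower number from compound 1 to compound 2 (0.40 log units; beyond the scatter), which swapped a saturated ring for an aromatic one; the present change keeps an aromatic ring and alters only its substituent, so that step gives no direct guide. Among the measured compounds shown here, no other pair in the data speaks to it. The expectation is accordingly a step of a 1.0-fold lower number from compound 2 to compound 3 (0.02 log units; within the scatter), that is, none beyond the scatter. Compound 3 is therefore estimated at 7000 nM, with a range from 2500 nM to 20000 nM.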

Compound 3, half-maximal inhibitory concentration: 8870 nM
The estimate for compound 3 lay 1.3-fold (0.10 log units) below the measured number; the measured number falls inside the stated range.
By their numbers in this assay, from the lowest: compounds 2 and 3 (each within the scatter of the next); then compound 1.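

In this assay, replacing 4-chlorophenyl with 3-nitrophenyl on the amine nitrogen gives a 1.2-fold higher number from compound 2 to compound 3 (0.09 log units; within the scatter), so this position tolerates a change of both the substituent and its place on the aromatic ring without a difference that can be told from the scatter. The comparison with the saturated ring now rests on a second aromatic group, since 3-nitrophenyl in place of cyclohexyl gives a 2.1-fold lower number from compound 1 to compound 3 (0.32 log units; beyond the scatter); among the three compounds, both aromatic groups sit beyond the scatter of cyclohexyl, and neither goes against this, though the step remains modest. Nothing available accounts for either result or says what the two aromatic groups have in common that matters here.

The compounds shown leave open how a plain phenyl group would compare, and whether the matching values of compound 2 and compound 3 would hold for 3-chlorophenyl or 4-nitrophenyl, which would separate the substituent from its place on the ring. They also leave open whether a group such as benzyl, or a phenyl ring carrying an amine or a carboxylic acid, would stay in the same range.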